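The compounds below may be only part of what the source reports. "The series", "measured", "known", "first", "only" and "open" are said of these compounds alone.

Measured so far:
compound 1 `COc1ccc(C(O)(Cc2ccc(F)cc2)c2cccc3ccccc23)c(OC)c1OC` — > 20000 nM
compound 2 `COc1ccc(/C(=N/OC(C)=O)c2cccc3ccccc23)c(OC)c1OC` — 4980 nM

The read-out is a functional assay on HCT-116 cells (Homo sapiens) for inhibition, read by sulforhodamine B assay, with a stated time of 48 h; a lower number here means a stronger inhibitor, a higher number a weaker inhibitor. For compound 1 the value > 20000 nM is a limit of the assay and not a number. Compound 2 gives a number, 4980 nM. Within the data shown here, the two compounds differ in more than one place, so no single step joins them, and nothing is drawn from the pair beyond what each value shows on its own. Where compound 1 stands is told by the limit of > 20000 nM in this assay, at which 1 of the 2 values shown sits.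

The unmeasured compound 3 `C=CCC(O)(c1ccc(OC)c(OC)c1OC)c1cccc2ccccc12` is compound 1 with vinyl in place of 4-fluorophenyl on a saturated chain carbon, two bonds along the chain from two aromatic carbons and an oxygen on a saturated carbon. Among the measured compounds shown here, no step between measured compounds covers this change, so its size is not known from the data. Compound 1 sits at the limit, so a further weakening could not be seen; only a strengthening beyond the scatter would appear as a number. Compound 3 is expected to stay near that limit, the step that the limit leaves unreadable from compound 1 to compound 3 being taken as none beyond the scatter. For compound 3 the estimate in this assay is 25000 nM, with a range from 8000 nM to 60000 nM.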

Compound 3, half-maximal inhibitory concentration: > 20000 nM
Compound 3 gave a limit, no number (the forecaster's own chance of this, stated with the estimate: 60%); the middle value lies beyond the limit too.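

Compound 1 and compound 3 both give only a limit of the assay and not a number, so no step can be read from the one to the other: the limit of > 20000 nM in this assay, at which 2 of the 3 values shown sit.

The compounds shown leave open the size, and even the direction, of the change from 4-fluorobenzyl to allyl on the shared core.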